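Replacing a Methylsulfanyl Group on the Core of Compound 1

A few compounds are considered here, and "the series" means these few. Any claim that something is new, unique, unknown or untested is made for them only; others in the source may bear on it.

Compound 1, with the structure `CSc1nc(N)c2nc(O)n(Cc3ccccc3)c2n1`, is the more potent of the two measured compounds in a functional assay (spleen, spleen) for activation, with Mus musculus as the target (a lower number here means that less compound is needed, a higher number that more compound is needed for the effect), where compound 1 gives 0.1 uM. Compound 2, with the structure `Cc1ccc(Cn2c(O)nc3c(N)ncnc32)cc1`, carries a different substituent pattern on the shared core, and in this assay compound 2 gives 10 uM, a number that stands well beyond the usual scatter from that of compound 1. For the measured compounds named here, no pair of measured compounds differing in a single place exists here, so no measured step can guide the next change directly.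

Compound 3, with the structure `CCCC[S+]([O-])c1nc(N)c2nc(O)n(Cc3ccccc3)c2n1`, is the unmeasured compound. It differs from compound 1 by a group of 6 heavy atoms (4 carbon, 1 oxygen, 1 sulfur; no ring) in place of a group of 2 heavy atoms (1 carbon, 1 sulfur; no ring), on an aromatic carbon. The change sits on an aromatic carbon between two ring nitrogen atoms, meta to an amino group.

Going by the values given here, since no measured step of this kind is available, the size of the change is uncertain, and the step from compound 1 to compound 3 is expected to be modest and toward a higher number, a 3.0-fold higher number from compound 1 to compound 3 (0.48 log units; beyond the scatter). Compound 3 is therefore estimated to give 0.3 uM in this assay, within a range from 0.03 uM to 3 uM.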

Compound 3, minimum effective concentration: 0.01 uM
Beside the measured number, compound 3's estimate is 30-fold (1.48 log units) above it; the whole stated range lies above it.
By their numbers in this assay, from the lowest: compound 3; then compound 1; then compound 2.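

The aromatic carbon between two ring nitrogen atoms accepts far more than methylsulfanyl: in this assay, the larger group of 6 heavy atoms gives a 10-fold lower number from compound 1 to compound 3 (1.00 log units; beyond the scatter). For the compounds shown here, compound 1 and compound 2 differ in more than one place, so they could not show what a change at this carbon alone does, and this is the first single-place step. Nothing measured here explains the gain.

The step adds carbon atoms to the chain and an oxygen on the sulfur at once, so it leaves open which of the two changes accounts for the lower number, a question that a butylsulfanyl group, with the same 4 carbon atoms and no oxygen, or a methyl chain keeping the oxygen on sulfur, would help to separate. Also open, from the compounds shown here alone, is whether the sulfur is needed at all, for example whether an amine or a plain alkyl chain at this carbon would give a number as low in this assay.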